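A Third Stereoisomer Awaits Its Inhibition Reading

The source may hold more compounds than are shown below. What is called first, only, known or untested is meant among the compounds shown, and "the series" means these compounds.

In an assay for inhibition of alpha-N-acetylgalactosaminidase (Gallus gallus), tested at 1000 uM (a lower number here means less inhibition, a higher number more inhibition at the concentration tested (going by the name of the read-out)), three close relatives have been measured so far. Compound 1, `O=C(O)[C@@H]1NCC=C[C@@H]1O`, gives 1.3%. Compound 2, `O=C(O)[C@@H]1NCC=C[C@H]1O`, gives 3.2%. Compound 3, `O=C(O)[C@@H]1NC[C@H](O)[C@@H](O)[C@H]1O`, gives 4%. Within the data shown here, the only single-place step among them runs a number 1.9 percentage points higher from compound 1 to compound 2 (within the scatter); the pairing rests on (the fact that compounds 1 and 2 differ only in the configuration as drawn), and the outcome is a shift too small to count. Compound 2 thus sits in the middle of the numbers shown, with compound 3 nearest to it and compound 1 furthest from it, yet every gap among the three lies within the usual scatter, so none of them can be set apart from the others on these data.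

Compound 4, `O=C(O)[C@H]1NCC=C[C@H]1O`, has not yet been measured. Against compound 2 its difference is the two compounds have the same atoms and bonds and differ only in configuration as drawn: 1 of 2 stereo elements differ; a stereocentre at a saturated ring carbon is drawn R in compound 2 and S in compound 4. Among the measured compounds shown here, the one measured step that bears on this, from compound 1 to compound 2, was itself a swap of configuration at a single stereocentre and produced no movement beyond the scatter; nothing in the present numbers points toward a different outcome for a second such swap. Compound 4 is therefore expected to give 3%, between 0% and 10%. In other words, the step of a number 0.2 percentage points lower from compound 2 to compound 4 (within the scatter) is expected to stay within the scatter.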

Compound 4, a percentage reported as inhibition, at one concentration (the size of the read-out at that concentration, not a potency): 0.2%
Compound 4: the middle estimate sits 2.8 percentage points above what was measured; measured number inside the range.
By their numbers in this assay, from the lowest: compounds 4, 1, 2 and 3 (each within the scatter of the next).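

In this assay the reading runs a number 3 percentage points lower from compound 2 to compound 4 (within the scatter), a change at the saturated ring carbon whose stereocentre stayed the same in the earlier single-place step. Inverting both stereocentres together, which turns one compound into its mirror image, gives the same picture, with the reading running a number 1.1 percentage points lower from compound 1 to compound 4 (within the scatter). Each stereocentre of the shared core has now been changed on its own, and the two have been changed together, without a shift that can be told from the scatter, and the new comparisons involve configuration alone: the fact that compounds 2 and 4 differ only in the configuration as drawn

All the readings shown are small at the single concentration tested, so they leave open whether configuration at either stereocentre would matter for a compound giving a much larger reading in this assay. Every compound shown also carries the carboxylic acid, so it remains open whether a methyl ester or an amide in its place would give a reading beyond the scatter, and whether any such reading would then depend on configuration.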